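From a Protected Amine Arm to a Benzoyl Group

A few compounds are considered here, and "the series" means these few. Any claim that something is new, unique, unknown or untested is made for them only; others in the source may bear on it.

Compound 1 `COc1ccc(N(CC(=O)NCCC[Te]c2ccccc2)C(=O)CNC(=O)OC(C)(C)C)cc1` carries a ((tert-butoxycarbonyl)amino)methyl group on a carbonyl carbon whose other neighbour is an amide-type nitrogen. In a functional assay on ACHN cells (Homo sapiens) for inhibition, with a stated time of 48 h (on this read-out higher numbers stand for lower toxicity in this test and lower numbers for higher toxicity in this test), compound 1 returns only a limit of the test, < 100000 nM. Compound 2 `COc1ccc(N(CC(=O)NCCC[Te]c2ccccc2)C(=O)CCSC2=C(C)C(=O)c3ccccc3C2=O)cc1`, a relative with a different group on that carbonyl, gives 6760 nM in this assay. Compound 3 `COc1ccc(N(CC(=O)NCCC[Te]c2ccccc2)C(=O)c2ccccc2)cc1` differs from compound 1 by phenyl in place of ((tert-butoxycarbonyl)amino)methyl on a carbonyl carbon. Among the compounds with values here, no measured pair shows this exact change, so its size is unknown. For compound 3 a value of 20000 nM is expected, within 5000 nM to 80000 nM. That estimate corresponds to an expected step that the limit leaves unreadable from compound 1 to compound 3.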

Compound 3, concentration lethal to 50% of the cells: 39800 nM
Beside the measured number, compound 3's estimate is 2.0-fold (0.30 log units) below it; measured number inside the range.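

No size can be read for the change from compound 1 to compound 3, because compound 1 gives only a limit: the limit of < 100000 nM in this assay, at which 1 of the 3 values shown sits.

As far as these compounds go, whether phenyl in place of ((tert-butoxycarbonyl)amino)methyl raises or lowers toxicity in this assay stays open.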